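A few compounds are considered here, and "the series" means these few. Any claim that something is new, unique, unknown or untested is made for them only; others in the source may bear on it.

Series notes. Compound 1 `CCc1cccc(CNC(=O)c2nc3ccc(F)c(COc4ccc(CC(=O)O)cc4)c3c(=O)[nH]2)c1`, compound 2 `CCc1cccc(CNC(=O)c2nc3cccc(COc4ccc(CC(=O)O)cc4)c3c(=O)[nH]2)c1` and compound 3 `CCc1cccc(CNC(=O)c2nc3cccc(COCc4ccc(C(=O)O)cc4)c3c(=O)[nH]2)c1` share one core; compound 4 `CCc1cccc(CNC(=O)c2nc3c(F)ccc(COCc4ccc(C(=O)O)cc4)c3c(=O)[nH]2)c1` is not yet measured. In an ADME assay on HEK293 cells (Homo sapiens) for cytotoxicity, read by resazurin assay, with a stated time of 72 h (a lower number here means that less compound is tolerated, a higher number that more compound is tolerated), compound 1 gives > 20000 nM, a limit of the assay. In this assay compound 2 gives > 20000 nM, also a limit. In this assay compound 3 gives > 40000 nM, again a limit. Compounds 1 and 2 sit at the limit of > 20000 nM in this assay, at which 2 of the 3 values shown sit. Compound 3 sits at the limit of > 40000 nM in this assay, at which 1 of the 3 values shown sits. The step that the two limits leave unreadable from compound 2 to compound 1 follows the change (fluoro in place of hydrogen on an aromatic carbon). The step that the two limits leave unreadable from compound 2 to compound 3 follows the change (4-carboxybenzyl in place of 4-(carboxymethyl)phenyl on an oxygen on a saturated carbon). The change from compound 3 to compound 4 is fluoro in place of hydrogen on an aromatic carbon, the same kind of change as that from compound 2 to compound 1, though the place differs: in compound 1 the fluoro stands ortho to a (4-(carboxymethyl)phenoxy)methyl group and para to a fused ring, in compound 4 ortho to a fused ring and para to a ((4-carboxybenzyl)oxy)methyl group. Since a step that the two limits leave unreadable from compound 2 to compound 1 stayed between limits, the step that the limit leaves unreadable from compound 3 to compound 4 is expected to be small. This expectation rests on compound 3, whose value > 40000 nM is a limit. Compound 4 is expected at 60000 nM, between 20000 nM and 200000 nM.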

Compound 4, half-maximal cytotoxic concentration: > 20000 nM
Compound 4: a limit, no number; the forecaster's own chance of this, stated with the estimate: 85%; the middle value does not contradict the limit.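

In this assay, for the compounds shown here, compound 3 and compound 4 both stand at limits of the assay, so no step between them can be read. The compounds shown leave open at what concentration any of them becomes cytotoxic, and whether fluoro in place of hydrogen changes that.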